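Notes on the amide series: compound 3 to compound 4

A few compounds are considered here, and "the series" means these few. Any claim that something is new, unique, unknown or untested is made for them only; others in the source may bear on it.

Measured so far in an in vitro assay on HEK-tsA201 cells for antagonist activity at Neuronal acetylcholine receptor; alpha4/beta2 (Homo sapiens), read by fluorescence and calcium flux; on this read-out lower numbers stand for stronger inhibition and higher numbers for weaker inhibition: compound 1 `C=C(C)COc1ccc(C(=O)Nc2cccc(C)n2)cc1` gives 19600 nM; compound 2 `C=CCOc1ccc(C(=O)Nc2cccc(Br)n2)cc1` gives 70100 nM; compound 3 `CCCOc1ccc(C(=O)Nc2cccc(Br)n2)cc1` gives 80700 nM.

Compound 3 holds the highest of the three numbers; compound 2 is nearest, and compound 1 is the furthest and well outside the scatter. Going by the values given here, the sole single-point step measured, a 1.2-fold higher number from compound 2 to compound 3 (0.06 log units; within the scatter), concerns the chain on the oxygen and stays within scatter.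

Compound 4 `CCCCCCNc1cccc(NC(=O)c2ccc(OCCC)cc2)n1` carries hexylamino in place of bromo on an aromatic carbon. Among the compounds with values here, no measured step touches this aromatic carbon, so the expectation rests on compound 3 alone, with a wide range: the step is estimated as a 2.0-fold lower number from compound 3 to compound 4 (0.30 log units; within the scatter), and compound 4 is expected near 40000 nM (range 8000 nM to 200000 nM) in this assay.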

Compound 4, half-maximal inhibitory concentration: > 100000 nM
Compound 4: a limit, no number; the forecaster's own chance of this, stated with the estimate: 25%; middle value at least 2.5-fold (0.39 log units) away from the limit.
By their numbers in this assay, from the lowest: compound 1; then compounds 2 and 3 (each within the scatter of the next). At a limit, above all of these: compound 4.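

Hexylamino in place of bromo, on the aromatic carbon next to the ring nitrogen, gives an at least 1.2-fold higher number from compound 3 to compound 4 (0.09 log units; that floor lies within the scatter), the first step measured at this position. In this assay compound 4 gives > 100000 nM, a limit and not a number: the limit of > 100000 nM in this assay, at which 1 of the 4 values shown sits. This change therefore shows no gain in inhibition, and the true size of the step cannot be read past that limit.

Open, from the compounds shown here alone, is whether a shorter group on this carbon, such as methylamino or a free amine, gives a readable number. Also open, going by these compounds, is whether an ether or a carboxylic acid there would do the same.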